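The source may report more compounds than this note shows. Statements on the series, on what has been measured and on what is new or still open speak of the compounds shown alone.

Working notes on the series. In a functional assay on K562 cells (Homo sapiens) for inhibition, read by trypan blue exclusion, with a stated time of 72 h (a lower number here means a stronger inhibitor, a higher number a weaker inhibitor), compound 2 (`Cn1c(=O)c(S(=O)(=O)c2ccc(Cl)cc2)cc2cnc(Nc3ccc4[nH]ccc4c3)nc21`) gives 100 nM, level with compound 3 (`Cn1c(=O)c(S(=O)(=O)c2ccc(O)cc2)cc2cnc(Nc3ccc4[nH]ccc4c3)nc21`) at 100 nM. Together they hold the lowest number of the three measured, while compound 1 (`Cn1c(=O)c(S(=O)(=O)c2ccc(C(=O)O)cc2)cc2cnc(Nc3ccc4[nH]ccc4c3)nc21`) gives 5000 nM.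

The open question is compound 4 (`Cn1c(=O)c(S(=O)(=O)c2ccc(Cl)cc2)cc2cnc(Nc3cccc4[nH]ccc34)nc21`), which carries 1H-indol-4-yl in place of 1H-indol-5-yl on a nitrogen on an aromatic ring.

The measured steps exchange only carboxy, chloro and hydroxy: a 50-fold lower number from compound 1 to compound 2 (1.70 log units; beyond the scatter), a 50-fold lower number from compound 1 to compound 3 (1.70 log units; beyond the scatter) and no change at the digits printed from compound 2 to compound 3 (within the scatter). The first two are large and the third lies within the scatter. None alters the indolyl group, so they bear on this change only indirectly, showing that one exchange can move this assay a long way. The data hold no direct measure of the new attachment, so a moderate rise is expected, with a wide margin.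

The expected step is a 2.5-fold higher number from compound 2 to compound 4 (0.40 log units; beyond the scatter). For compound 4 the estimated value is 250 nM, with an expected range of 60 nM to 1500 nM.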

Compound 4, half-maximal inhibitory concentration: 5000 nM
Compound 4: middle estimate off by 20-fold (1.30 log units), on the low side; the whole stated range lies below it.
By their numbers in this assay, from the lowest: compounds 2 and 3 (each within the scatter of the next); then compounds 1 and 4 (each within the scatter of the next).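

In this assay, the change of attachment from 1H-indol-5-yl to 1H-indol-4-yl gives a 50-fold higher number from compound 2 to compound 4 (1.70 log units; beyond the scatter) and is a large step. Among these compounds, the earlier compounds varied only carboxy, chloro and hydroxy, so this is the first evidence that the group on the nitrogen is also sensitive. Here the two groups have the same atoms joined differently, and the step matches in size the largest of the earlier exchanges. Nothing measured here accounts for this step.

Still open, from the compounds shown here alone, is whether the same step would appear with hydroxy, as in compound 3, in place of the chloro of compound 2. The compounds shown also leave open how other groups on that nitrogen, such as 1H-indol-6-yl or a plain phenyl, would compare with 1H-indol-5-yl.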